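Replacing a Flexible Arm with a Dichlorophenyl Ring

This account rests on a few compounds, and the source may have more. Where it says the series, first, only, none or still open, it means among the compounds named here.

Three compounds share one core and differ only in the group on an amine nitrogen in a ring. Compound 1 `Nc1scc(CN2CCN(c3ccccc3F)CC2)c1C(=O)c1ccc(Cl)cc1` gives 0% in an assay on CHO cells for displacement of a labelled ligand from adenosine receptor A3 (Homo sapiens), read by scintillation counting, with a stated time of 120 min, tested at 10 uM; on this read-out higher numbers stand for more inhibition at the one concentration tested (going by the name of the read-out) and lower numbers for less inhibition. Compound 2 `Nc1scc(CN2CCN(c3c(F)cccc3F)CC2)c1C(=O)c1ccc(Cl)cc1` gives 4% in this assay, and compound 3 `Nc1scc(CN2CCN(CCCc3ccc(Cl)cc3)CC2)c1C(=O)c1ccc(Cl)cc1` gives 0%. Compound 3 therefore stands level with compound 1 at the lowest of the three numbers; the step of no change at the digits printed from compound 1 to compound 3 (within the scatter) and the step of a number 4 percentage points lower from compound 2 to compound 3 (within the scatter) both lie within the scatter, so none of the three swaps on the ring nitrogen moved this assay.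

Compound 4 `Nc1scc(CN2CCN(c3ccc(Cl)c(Cl)c3)CC2)c1C(=O)c1ccc(Cl)cc1` differs from compound 3 by 3,4-dichlorophenyl in place of 3-(4-chlorophenyl)propyl on an amine nitrogen in a ring. Going by the values given here, the steps that bear on this are the two swaps already seen on the same nitrogen, no change at the digits printed from compound 1 to compound 3 (within the scatter) and a number 4 percentage points lower from compound 2 to compound 3 (within the scatter), both flat. The expectation is a step of a number 2 percentage points higher from compound 3 to compound 4 (within the scatter), that is, no change beyond the scatter. Compound 4 is therefore estimated at 2%, with a range from -8% to 15%.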

Compound 4, a percentage reported as inhibition, at one concentration (the size of the read-out at that concentration, not a potency): 3%
Compound 4: middle estimate off by 1 percentage points, on the low side; measured number inside the range.
By their numbers in this assay, from the lowest: compounds 1, 3, 4 and 2 (each within the scatter of the next).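

With compound 4, the amine nitrogen in the ring now carries a phenyl ring with two chlorines, and this assay still stays flat (a number 3 percentage points higher from compound 3 to compound 4 (within the scatter); a number 1 percentage points lower from compound 2 to compound 4 (within the scatter); a number 3 percentage points higher from compound 1 to compound 4 (within the scatter)). Among these four compounds, then, neither removing the propyl chain of compound 3 nor changing from fluoro to chloro substituents on the phenyl ring moves the number beyond the scatter. No measurement shown here explains these flat results.

All four numbers lie close to zero at the one concentration tested, so the compounds shown cannot reveal which features at this position would raise the inhibition. Going by these compounds, whether a carboxylic acid, a primary amine or a longer chain ending in a hydroxyl group on this nitrogen would change the reading remains open.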